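Para-substituent scan on the sulfonyl phenyl: cytotoxicity

The source may report more compounds than this note shows. Statements on the series, on what has been measured and on what is new or still open speak of the compounds shown alone.

Working notes on a small set sharing one core. Compound 1 `O=C1/C(=C/c2ccccc2F)CN(S(=O)(=O)c2ccccc2)C/C1=C\c1ccccc1F` gives 17600 nM in an ADME assay on L02 cells (Homo sapiens) for cytotoxicity, read by MTT assay, with a stated time of 24 h; on this read-out lower numbers stand for stronger inhibition and higher numbers for weaker inhibition. Compound 2 `O=C1/C(=C/c2ccccc2F)CN(S(=O)(=O)c2ccc(O[N+](=O)[O-])cc2)C/C1=C\c1ccccc1F` gives 15500 nM in this assay, and compound 3 `O=C1/C(=C/c2ccccc2F)CN(S(=O)(=O)c2ccc(C(F)(F)F)cc2)C/C1=C\c1ccccc1F` gives 16200 nM. The three numbers sit together: the step of a 1.1-fold lower number from compound 1 to compound 2 (0.06 log units; within the scatter) and the step of a 1.1-fold lower number from compound 1 to compound 3 (0.04 log units; within the scatter) are both within the scatter, as is the step of a 1.0-fold higher number from compound 2 to compound 3 (0.02 log units; within the scatter). Compound 2 therefore cannot be set apart from compound 1 or compound 3 on these numbers; all three read as one level.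

The next member, compound 4 `CC(=O)Nc1ccc(S(=O)(=O)N2C/C(=C\c3ccccc3F)C(=O)/C(=C/c3ccccc3F)C2)cc1`, is not yet measured in this assay. Relative to compound 2 the change is acetamido in place of nitrooxy on an aromatic carbon, that is, 4-(nitrooxy)phenyl becomes 4-acetamidophenyl, with one hydrogen-bond donor now present where the nitrooxy had none.

Both earlier steps at this same aromatic carbon, hydrogen to nitrooxy and hydrogen to trifluoromethyl, left this assay unchanged within the scatter. Within the data shown here, no measured step addresses an acetamido group, so the donor it brings is untested here. On the evidence of compound 2 at 15500 nM and its neighbours, the expected step is a 1.0-fold higher number from compound 2 to compound 4 (0.01 log units; within the scatter), no larger than the scatter. Compound 4 is therefore estimated at 16000 nM, with a range from 8000 nM to 32000 nM.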

Compound 4, half-maximal inhibitory concentration: 11500 nM
Estimate against measurement, compound 4: 1.4-fold (0.14 log units) above; low and high end bracket the measured number.
By their numbers in this assay, from the lowest: compounds 4, 2, 3 and 1 (each within the scatter of the next).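

The acetamido group is the only one in this set that brings a hydrogen-bond donor, and at this aromatic carbon it also stays within the scatter in this assay: a 1.3-fold lower number from compound 2 to compound 4 (0.13 log units; within the scatter), a 1.4-fold lower number from compound 3 to compound 4 (0.15 log units; within the scatter) and a 1.5-fold lower number from compound 1 to compound 4 (0.18 log units; within the scatter). Among these compounds, the position para to a large group now holds hydrogen, nitrooxy, trifluoromethyl and acetamido at one level, so adding the donor gives no step that can be separated from the scatter in these compounds. No measurement at hand offers an explanation for this flat read-out.

An amine, a carboxylic acid or a longer chain at this aromatic carbon lies outside the compounds shown, so it remains open whether any group here can move the number beyond the scatter. The rest of the shared core stays the same from compound 1 to compound 4, which leaves open how far the cytotoxicity read-out depends on the core rather than on this substituent.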